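Azido in place of hydroxy on the pendant aromatic ring

The source may report more compounds than this note shows. Statements on the series, on what has been measured and on what is new or still open speak of the compounds shown alone.

Measured compounds:
compound 1, `Cc1nn(C)c2c1C(c1ccccc1)=NCCN2`, 2.5 mg/kg
compound 2, `Cc1nn(C)c2c1C(c1cccc(Br)c1)=NCCN2`, 0.63 mg/kg
compound 3, `Cc1nn(C)c2c1C(c1cccc(O)c1)=NCCN2`, 2.5 mg/kg

In a functional assay on the whole organism for positive allosteric modulation, with Rattus norvegicus as the target (a higher number here means that more compound is needed for the effect, a lower number that less compound is needed), compound 3 stands level with compound 1 at the digits given, and together these two are the highest numbers of the three. Going by the values given here, the only step beyond the scatter at this position of the ring is a 4.0-fold lower number from compound 1 to compound 2 (0.60 log units; beyond the scatter), mirrored as a 4.0-fold higher number from compound 2 to compound 3 (0.60 log units; beyond the scatter); the step of no change at the digits printed from compound 1 to compound 3 (within the scatter) is within the scatter.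

Compound 4, `Cc1nn(C)c2c1C(c1cccc(N=[N+]=[N-])c1)=NCCN2`, differs from compound 3 by azido in place of hydroxy on an aromatic carbon. Among the compounds with values here, no azido group has been measured, so the steps that bear on it are only those at the same ring carbon. The step from hydrogen to bromo lowered the number by a modest amount, while hydroxy left it unchanged. For compound 4 the expectation is therefore a modest lowering in this assay, estimated as a 2.1-fold lower number from compound 3 to compound 4 (0.32 log units; beyond the scatter), but not the full size of the bromo step. Compound 4 is expected to give about 1.2 mg/kg, within a range of 0.5 mg/kg to 2.5 mg/kg.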

Compound 4, minimum effective dose: 2.5 mg/kg
Estimate against measurement, compound 4: 2.1-fold (0.32 log units) below, and the stated range covers the measured number.
By their numbers in this assay, from the lowest: compound 2; then compounds 1, 3 and 4 (each within the scatter of the next).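

In this assay, going by these compounds alone, azido at this ring carbon stays level with hydrogen (no change at the digits printed from compound 1 to compound 4 (within the scatter)) and with hydroxy (no change at the digits printed from compound 3 to compound 4 (within the scatter)), so bromo is now the one group of the three substituents that stands apart (a 4.0-fold higher number from compound 2 to compound 4 (0.60 log units; beyond the scatter)). In the step from compound 3 to compound 4, three heavy atoms replace one and the hydrogen-bond donor of hydroxy is gone, yet the number shows no shift beyond the scatter. No supporting data bear on why bromo stands apart from azido and hydroxy at this position.

From the compounds shown here alone, whether the lowering seen with bromo carries over to chloro, iodo or trifluoromethyl at this ring carbon remains open. So does whether an amine or a carboxylic acid there would stay level with hydrogen, and how any of these groups would behave elsewhere on the ring.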